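The source may hold more compounds than are shown below. What is called first, only, known or untested is meant among the compounds shown, and "the series" means these compounds.

Two compounds built on a shared core were examined in an ADME assay on BaF3 cells (Mus musculus) for cytotoxicity, read by MTT assay, with a stated time of 48 h; a higher number here means a weaker inhibitor of growth, a lower number a stronger inhibitor of growth. Compound 1 `CC(C)n1nc(-c2cc(-c3ccccc3)on2)c2c(N)ncnc21` gives in this assay a value of > 10000 nM, which is a limit of the assay and not a measured number. Compound 2 `Nc1ncnc2c1c(-c1cc(C3CC3)on1)nn2C1CCOCC1` gives in this assay a value of > 10000 nM, again a limit rather than a number. Going by the values given here, both values sit at the limit of > 10000 nM in this assay, at which 2 of the 2 values shown sit, so compound 2 stands at the edge of what this assay reports, with no number to place it against compound 1, and no step between the two measured compounds can be sized.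

Compound 3 `Cn1nc(-c2cc(C3CC3)on2)c2c(N)ncnc21` differs from compound 2 in one place: methyl in place of oxan-4-yl on an aromatic nitrogen. The change is a methyl in place of oxan-4-yl on an aromatic nitrogen, with the rest of compound 2 kept.

Since both measured compounds reach only the limit, the step from compound 2 to compound 3 is expected to be a number no higher from compound 2 to compound 3 (the limit leaves the size open), none beyond the scatter, in this assay. Compound 3 is therefore estimated to give 10000 nM in this assay, with a range from 4000 nM to 30000 nM, most likely reported again as a limit.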

Compound 3, concentration for 50% growth inhibition: > 10000 nM
Compound 3: no number, only a limit; the forecaster's own chance of this, stated with the estimate: 80%; the middle value sits exactly at the limit.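

In this assay compound 3 gives > 10000 nM, which is a limit and not a number. The step between compound 2 and compound 3 cannot be read, because all the values stop at the same point: the limit of > 10000 nM in this assay, at which 3 of the 3 values shown sit.

The compounds shown leave open whether methyl and oxan-4-yl differ at all in this assay.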